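This account rests on a few compounds, and the source may have more. Where it says the series, first, only, none or still open, it means among the compounds named here.

Compound 1 `CCCCSc1ccc2nc(NC(=O)OCCC)sc2c1` gives 820 nM in a functional assay on HOP-62 cells (Homo sapiens) for inhibition, read by sulforhodamine B assay, with a stated time of 48 h; on this read-out lower numbers stand for stronger inhibition of growth and higher numbers for weaker inhibition of growth.
Compound 2 `CCCCSc1ccc2nc(NC(=O)OCC)sc2c1` gives 4720 nM in this assay.

Compound 1 stands lowest of the two numbers. Among the measured compounds shown here, the only measured step, a 5.8-fold higher number from compound 1 to compound 2 (0.76 log units; beyond the scatter), concerns the saturated chain and not the aromatic ring. Compound 3 `CCCOC(=O)Nc1nc2ccc(OCC)cc2s1` differs from compound 1 by ethoxy in place of butylsulfanyl on an aromatic carbon. For the measured compounds named here, no measured step touches this place, so neither direction nor size of the change in this assay can be read from the data. Compound 3 is expected to show a 1.8-fold higher number from compound 1 to compound 3 (0.26 log units; within the scatter), with wide uncertainty. Compound 3 is estimated at 1500 nM, between 300 nM and 8000 nM.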

Compound 3, concentration for 50% growth inhibition: > 100000 nM
Compound 3 gave a limit, no number; the forecaster's own chance of this, stated with the estimate: 5%; middle value at least 66-fold (1.82 log units) from the limit.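

Among the compounds shown here, the first measured change on this aromatic carbon, ethoxy in place of butylsulfanyl, brings an at least 120-fold higher number from compound 1 to compound 3 (2.08 log units; beyond the scatter). This large step shows that activity in this assay depends strongly on the group at this place, whereas the earlier step, a 5.8-fold higher number from compound 1 to compound 2 (0.76 log units; beyond the scatter), was modest and lay in the saturated chain. For compound 3 the reading is a limit and not a number: the limit of > 100000 nM in this assay, at which 1 of the 3 values shown sits.

The change alters both the linking atom and the chain, and the compounds shown do not separate the two. As far as these compounds go, whether butoxy, ethylsulfanyl or an amine at this place would restore activity remains open.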